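From 4-fluorophenyl to 2-chlorophenyl in a small series

A few compounds are considered here, and "the series" means these few. Any claim that something is new, unique, unknown or untested is made for them only; others in the source may bear on it.

In a functional assay on KB cells (Homo sapiens) for cytotoxicity, read by MTT assay, with a stated time of 72 h (a lower number here means that less compound is needed, a higher number that more compound is needed for the effect), compound 1 (`COc1ccc(/C=C2\C(=O)N(c3c(Cl)cccc3Cl)c3ccccc32)cc1OC`) gives 10 ug/mL and compound 2 (`O=C1/C(=C\c2ccc(F)cc2)c2ccccc2N1c1c(Cl)cccc1Cl`) gives 5 ug/mL, which places compound 2 level with compound 1 within the usual scatter. Compound 3 (`O=C1/C(=C\c2ccccc2Cl)c2ccccc2N1c1c(Cl)cccc1Cl`) carries 2-chlorophenyl in place of 4-fluorophenyl on a double-bonded chain carbon bound to a double-bonded ring carbon. Within the data shown here, no measured pair shows this change, so no step beyond the scatter is expected in this assay, and the estimated step is a 1.2-fold higher number from compound 2 to compound 3 (0.08 log units; within the scatter). The expected value for compound 3 is 6 ug/mL, with an estimated range from 2 ug/mL to 18 ug/mL.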

Compound 3, concentration for half-maximal effect: 5 ug/mL
Beside the measured number, compound 3's estimate is 1.2-fold (0.08 log units) above it; measured number inside the range.
By their numbers in this assay, from the lowest: compounds 2, 3 and 1 (each within the scatter of the next).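

In this assay, putting 2-chlorophenyl in place of 4-fluorophenyl on a double-bonded chain carbon bound to a double-bonded ring carbon gives no change at the digits printed from compound 2 to compound 3 (within the scatter). At this position, then, the two halogen-bearing phenyl groups read alike, although the halogen and its place on the ring change together, so the two changes cannot be separated. No measurement shown offers a reason for this result. Left open is whether a phenyl group carrying an amine or a carboxylic acid would read the same in this assay.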